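The source may hold more compounds than are shown below. What is called first, only, known or untested is meant among the compounds shown, and "the series" means these compounds.

Measured in a functional assay on Huh-7 cells (Homo sapiens) for cytotoxicity, read by MTT assay, with a stated time of 3 days; a lower number here means that less compound is tolerated, a higher number that more compound is tolerated:
- compound 1 `OC[C@H]1O[C@@H](n2cnc3c(COc4ccccc4)ncnc32)[C@H](O)[C@@H]1O`: > 100000 nM, a limit
- compound 2 `OC[C@H]1O[C@@H](n2cnc3c(Cn4cccn4)ncnc32)[C@H](O)[C@@H]1O`: > 250000 nM, a limit
- compound 3 `OCCSCc1ncnc2c1ncn2[C@@H]1O[C@H](CO)[C@@H](O)[C@H]1O`: > 100000 nM, a limit

Among the measured compounds shown here, no compound in this small set has yet given a number in this assay. Compound 3 is known only by the limit > 100000 nM. It belongs to the limit of > 100000 nM in this assay, at which 2 of the 3 values shown sit. The remaining value is the limit of > 250000 nM in this assay, at which 1 of the 3 values shown sits.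

The next compound is compound 4 `OC[C@H]1O[C@@H](n2cnc3c(CN4CCCCC4)ncnc32)[C@H](O)[C@@H]1O`. It differs from compound 3 by piperidin-1-yl in place of (2-hydroxyethyl)sulfanyl on a saturated chain carbon bound to an aromatic carbon. In words, piperidin-1-yl stands in place of (2-hydroxyethyl)sulfanyl on a saturated chain carbon bound to an aromatic carbon.

For the measured compounds named here, three measured steps bear on this change, as each swaps the group at that same place: a step that the two limits leave unreadable from compound 1 to compound 2, a step that the two limits leave unreadable from compound 1 to compound 3 and a step that the two limits leave unreadable from compound 2 to compound 3. None of them has a readable size, so they give no measured size or direction to carry over. Phenoxy, 1H-pyrazol-1-yl and (2-hydroxyethyl)sulfanyl all left the compounds at limits, and compound 4 is therefore expected to behave in the same way in this assay, most likely giving another limit. The expected change, a number no higher from compound 3 to compound 4 (the limit leaves the size open), is an estimate with no firm direction. For compound 4 the half-maximal cytotoxic concentration is estimated at 100000 nM, with an expected range of 30000 nM to 250000 nM.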

Compound 4, half-maximal cytotoxic concentration: 87000 nM
For compound 4 the middle estimate is 1.1-fold (0.06 log units) above the measured one; measured number inside the range.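

In this assay compound 4, with piperidin-1-yl on a saturated chain carbon bound to an aromatic carbon, gives a true number, 87000 nM, the first in this set that is not a limit. Among the compounds shown here, the steps among compound 1, compound 2 and compound 3 cannot be read, so this change is the first at this place to show a direction, towards a lower number, though the limits leave its full size open. The clearest reading is an at least 2.8-fold lower number from compound 2 to compound 4 (0.45 log units; beyond the scatter), while the other two readings are weaker: an at least 1.1-fold lower number from compound 3 to compound 4 (0.06 log units; that floor lies within the scatter) and an at least 1.1-fold lower number from compound 1 to compound 4 (0.06 log units; that floor lies within the scatter).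

No measurement shown gives a cause for this change. From the compounds shown here alone, it remains open how far compound 1, compound 2 and compound 3 truly lie from compound 4, and whether another amine on the same saturated chain carbon, such as morpholin-4-yl or an open-chain diethylamino group, would also give a number rather than a limit.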